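This account rests on a few compounds, and the source may have more. Where it says the series, first, only, none or still open, it means among the compounds named here.

Measured compounds:
- Compound 1, `CC(=O)Nc1nc(-c2cccc(NS(=O)(=O)c3ccc(C#CC4CCCCC4)cc3)c2)cs1`: in a functional assay on A-375 cells (Homo sapiens) for antiproliferative activity, read by trypan blue exclusion, with a stated time of 48 h, tested at 10 uM (a lower number here means a stronger effect, a higher number a weaker effect of the compound at the concentration tested), compound 1 gives 1.2%.
- Compound 2, `CC(=O)Nc1nc(-c2cccc(NS(=O)(=O)c3ccc(C#C[Si](C)(C)C)cc3)c2)cs1`: in this assay compound 2 gives < 1%, which is a limit of the assay rather than a number.

Compound 2 thus stands at the floor of what this assay can report, where one of the two readings sits (the limit of < 1% in this assay, at which 1 of the 2 values shown sits). Only a limit is known for it, and its reading and that of compound 1 lie within the usual scatter of each other, as the step of a number at least 0.2 percentage points lower from compound 1 to compound 2 (that floor lies within the scatter) shows: swapping the ring for the silicon-bearing group on the triple-bonded carbon changed nothing that can be told apart from noise.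

Compound 3, `CC(=O)Nc1nc(-c2cccc(NS(=O)(=O)c3ccc(C#CCCc4ccccc4)cc3)c2)cs1`, has not yet been measured. It differs from compound 2 in one place: a group of 8 heavy atoms (8 carbon; one six-membered aromatic ring of carbon only) in place of a group of 4 heavy atoms (3 carbon, 1 silicon; no ring), on a triple-bonded carbon. Among the measured compounds shown here, the only measured step at this place is a number at least 0.2 percentage points lower from compound 1 to compound 2 (that floor lies within the scatter), and it did not leave the scatter. A new group on the same triple-bonded carbon is therefore expected to give no step beyond the scatter either; the expected step is a number at least 1 percentage points higher from compound 2 to compound 3 (that floor lies within the scatter). Compound 3 is accordingly estimated at 2%, with a range from 0% to 12%, and it may well return only as a limit again.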

Compound 3, a percentage reported as activity, at one concentration (the size of the read-out at that concentration, not a potency): < 1%
Compound 3: only a limit was reported; the forecaster's own chance of this, stated with the estimate: 40%; at least 1 percentage points between middle value and limit.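

Compound 3 gives < 1% in this assay, and this is a limit of the assay, not a number. With phenethyl in place of cyclohexyl on the triple-bonded carbon, the result is a number at least 0.2 percentage points lower from compound 1 to compound 3 (that floor lies within the scatter), so this swap, like the earlier one, cannot be told apart from noise, and a group carrying an aromatic ring reads no differently from the non-aromatic ring of compound 1. The step between compound 2 and compound 3 cannot be read, and the floor of the read-out now holds most of the compounds shown: the limit of < 1% in this assay, at which 2 of the 3 values shown sit.

So far, then, the three groups on the triple-bonded carbon give no sign of how this position affects the reading, and a single tested concentration cannot rank them. Going by these compounds, whether a polar group such as an amine or a carboxylic acid, or a plain hydrogen, on that carbon would lift the reading clear of the scatter stays open, as does whether compound 1, compound 2 and compound 3 would separate at lower concentrations.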